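Cyclobutyl for cyclopropyl on the amide of compound 3

This account rests on a few compounds, and the source may have more. Where it says the series, first, only, none or still open, it means among the compounds named here.

Measured in a functional assay on OVCAR-8 cells (Homo sapiens) for antiproliferative activity; on this read-out higher numbers stand for weaker inhibition and lower numbers for stronger inhibition:
- compound 1 `CNC(=O)C[C@@H]1C[C@@H](c2ccc(Cl)c(Cl)c2)[C@H](NC(=O)c2cc(-c3c(Cl)cnn3C)c(Cl)o2)CN1`: 1130 nM
- compound 2 `Cn1ncc(Cl)c1-c1cc(C(=O)N[C@@H]2CN[C@H](CCn3cncn3)C[C@H]2c2ccc(Cl)c(Cl)c2)oc1Cl`: 1560 nM
- compound 3 `Cn1ncc(Cl)c1-c1cc(C(=O)N[C@@H]2CN[C@H](CC(=O)NC3CC3)C[C@H]2c2ccc(Cl)c(Cl)c2)oc1Cl`: 580 nM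

Compound 3 has the lowest number of the three, though only a 2.7-fold lower number from compound 2 to compound 3 (0.43 log units; beyond the scatter) exceeds the scatter, while a 1.9-fold lower number from compound 1 to compound 3 (0.29 log units; within the scatter) does not. Compound 4 `Cn1ncc(Cl)c1-c1cc(C(=O)N[C@@H]2CN[C@H](CC(=O)NC3CCC3)C[C@H]2c2ccc(Cl)c(Cl)c2)oc1Cl` has cyclobutyl in place of cyclopropyl on an amide-type nitrogen. The closest evidence is the methyl to cyclopropyl change at that same nitrogen, a 1.9-fold lower number from compound 1 to compound 3 (0.29 log units; within the scatter), which stayed within the scatter. The triazolyl side chain of compound 2 bears on this change less directly. No clear shift is therefore expected, and the estimate is a 1.1-fold lower number from compound 3 to compound 4 (0.05 log units; within the scatter). For compound 4 the estimated value in this assay is 520 nM, with an expected range of 250 nM to 1100 nM.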

Compound 4, half-maximal inhibitory concentration: 610 nM
The estimate for compound 4 lay 1.2-fold (0.07 log units) below the measured number, and the stated range covers the measured number.
By their numbers in this assay, from the lowest: compounds 3, 4, 1 and 2 (each within the scatter of the next, the first and the last beyond it).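

In this assay, cyclobutyl on the amide-type nitrogen behaved like cyclopropyl (a 1.1-fold higher number from compound 3 to compound 4 (0.02 log units; within the scatter)) and stayed within the scatter of methyl as well (a 1.9-fold lower number from compound 1 to compound 4 (0.27 log units; within the scatter)), so all three groups at this nitrogen gave values within the scatter of their neighbours. Like cyclopropylcarbamoyl, cyclobutylcarbamoyl also gave a lower number than the triazolyl chain (a 2.6-fold lower number from compound 2 to compound 4 (0.41 log units; beyond the scatter)). No measurement on hand accounts for these steps.

From the compounds shown here alone, whether a cyclohexyl ring, a phenyl ring or a chain ending in an amine on this nitrogen would move the number beyond the scatter remains open.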